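Swapping methoxy for fluoro at the assay limit

The compounds below may be only part of what the source reports. "The series", "measured", "known", "first", "only" and "open" are said of these compounds alone.

Measured so far in an ADME assay on HeLa cells (Homo sapiens) for cytotoxicity, read by crystal violet staining, with a stated time of 72 h; on this read-out higher numbers stand for lower toxicity in this test and lower numbers for higher toxicity in this test
compound 1 `CCOC(=O)c1cc(CCCOc2c(C)cc(-c3noc(C(F)(F)F)n3)cc2C)on1` gives 17200 nM
compound 2 `CCOC(=O)c1cc(CCCOc2ccc(-c3noc(C(F)(F)F)n3)cc2)on1` gives > 100000 nM as a limit
compound 3 `CCOC(=O)c1cc(CCCOc2ccc(-c3noc(C(F)(F)F)n3)cc2OC)on1` gives > 100000 nM as a limit

Compound 3 has no exact number, only a limit, reported as > 100000 nM in this test. This is the limit of > 100000 nM in this assay, at which 2 of the 3 values shown sit, and only compound 1 gives a true number. Compound 4 `CCOC(=O)c1cc(CCCOc2ccc(-c3noc(C(F)(F)F)n3)cc2F)on1` carries fluoro in place of methoxy on an aromatic carbon. Within the data shown here, the only measured step bearing on this place is a step that the two limits leave unreadable from compound 2 to compound 3 and so offers no size to carry over. No shift beyond the usual scatter is expected, and no direction can be read from the data. The expected step is a number no higher from compound 3 to compound 4 (the limit leaves the size open) and it may not be readable. Compound 4 is estimated at 100000 nM (range 40000 nM to 150000 nM) and may well return only the limit.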

Compound 4, half-maximal cytotoxic concentration: 60200 nM
Compound 4: the middle estimate sits 1.7-fold (0.22 log units) above what was measured, within the range that was stated.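

In this assay, fluoro gives this position its first exact number, whereas hydrogen and methoxy there give only limits. Replacing methoxy with fluoro gives an at least 1.6-fold lower number from compound 3 to compound 4 (0.22 log units; that floor lies within the scatter), and replacing hydrogen with fluoro gives an at least 1.6-fold lower number from compound 2 to compound 4 (0.22 log units; that floor lies within the scatter). Both steps are only floors, set by a limit shared by two compounds: the limit of > 100000 nM in this assay, at which 2 of the 4 values shown sit.

The step between those two limits still cannot be read. The compounds shown leave open how chloro or an amine at this position would read in this assay.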